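Indol-3-yl in Place of Pyridin-4-yl on the Hydrazone

A few compounds are considered here, and "the series" means these few. Any claim that something is new, unique, unknown or untested is made for them only; others in the source may bear on it.

Compound 1 `CN(C)C/C=C/C(=O)Nc1cccc(Nc2nc(N/N=C/c3ccccc3F)ncc2Cl)c1`: 3660 nM
Compound 2 `CN(C)C/C=C/C(=O)Nc1cccc(Nc2nc(N/N=C/c3ccncc3)ncc2Cl)c1`: 25200 nM

Two compounds share one core and differ only in the aromatic ring on a carbon with a double bond to nitrogen. In an ADME assay on HT-29 cells (Homo sapiens) for inhibition, read by MTT assay, with a stated time of 72 h (on this read-out higher numbers stand for weaker inhibition and lower numbers for stronger inhibition), compound 1 gives 3660 nM, and compound 2 gives 25200 nM, the higher of the two numbers. The step of a 6.9-fold higher number from compound 1 to compound 2 (0.84 log units; beyond the scatter) shows that swapping the 2-fluorophenyl for pyridin-4-yl weakened inhibition by a modest but real margin.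

Compound 3 `CN(C)C/C=C/C(=O)Nc1cccc(Nc2nc(N/N=C/c3c[nH]c4ccccc34)ncc2Cl)c1` is not yet measured. It differs from compound 2 by 1H-indol-3-yl in place of pyridin-4-yl on a carbon with a double bond to nitrogen. Among the compounds with values here, only one measured step bears on this position, and it shows that the ring here matters. Since compound 2 stands at the weak end of the pair, replacing pyridin-4-yl by 1H-indol-3-yl is expected to move the number back down, with a step estimated as a 7.2-fold lower number from compound 2 to compound 3 (0.86 log units; beyond the scatter). Compound 3 is therefore expected to give about 3500 nM in this assay, within a range from 800 nM to 15000 nM.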

Compound 3, half-maximal inhibitory concentration: 9680 nM
Estimate against measurement, compound 3: 2.8-fold (0.44 log units) below; the measured number falls inside the stated range.
By their numbers in this assay, from the lowest: compound 1; then compound 3; then compound 2.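

In this assay, 1H-indol-3-yl recovers only part of the loss seen with pyridin-4-yl, with a 2.6-fold lower number from compound 2 to compound 3 (0.42 log units; beyond the scatter) in this direction, yet a 2.6-fold higher number from compound 1 to compound 3 (0.42 log units; beyond the scatter) shows that it does not return to the level of 2-fluorophenyl. The three rings at this position therefore fall into a clear order, with each gap beyond the scatter, and the larger two-ring 1H-indol-3-yl sits in the middle rather than at either end, so ring size alone does not set the order among these compounds. Nothing available explains why the rings rank this way.

The compounds shown leave open how much of the lower number for compound 1 depends on its fluorine, which plain phenyl would help to test. They also leave open whether the indole hydrogen on nitrogen matters, which 1-methylindol-3-yl would help to test.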